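Thiophene-to-furan exchange on the shared core

The source may report more compounds than this note shows. Statements on the series, on what has been measured and on what is new or still open speak of the compounds shown alone.

Measured so far in a functional assay on T47D cells (Homo sapiens) for cytotoxicity, read by CCK-8 assay; on this read-out higher numbers stand for weaker inhibition and lower numbers for stronger inhibition:
compound 1 `Oc1ccc(-c2cc(-c3ccsc3)cc(-c3ccccc3O)n2)cc1`: > 50000 nM, a limit of the assay
compound 2 `Oc1ccc(-c2cc(-c3ccsc3)cc(-c3cccc(O)c3)n2)cc1`: 760 nM

Going by the values given here, compound 2 holds the only real number in this assay. Compound 1 stops at the limit of > 50000 nM in this assay, at which 1 of the 2 values shown sits, there. Among the compounds with values here, the single measured step, an at least 65-fold lower number from compound 1 to compound 2 (1.81 log units; beyond the scatter), concerns the hydroxyphenyl group and not the five-membered ring.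

Compound 3 `Oc1ccc(-c2cc(-c3ccco3)cc(-c3cccc(O)c3)n2)cc1` differs from compound 2 by furan-2-yl in place of thiophen-3-yl on an aromatic carbon. Within the data shown here, no measured step covers this exchange; the only step recorded, an at least 65-fold lower number from compound 1 to compound 2 (1.81 log units; beyond the scatter), sits at a different position and is of no direct use here. With nothing to point either way, no step beyond the scatter is expected in this assay for the change from compound 2 to compound 3. Compound 3 is therefore expected to give about 1000 nM, with a range of 300 nM to 3500 nM. The estimated step of a 1.3-fold higher number from compound 2 to compound 3 (0.12 log units; within the scatter) is expected to stay within the scatter.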

Compound 3, half-maximal inhibitory concentration: 1280 nM
Estimate against measurement, compound 3: 1.3-fold (0.11 log units) below; measured number inside the range.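

Going by these compounds alone, the exchange of thiophen-3-yl for furan-2-yl, opposite the ring nitrogen, gives in this assay a 1.7-fold higher number from compound 2 to compound 3 (0.23 log units; within the scatter) and so provides the first measured step at the five-membered ring. Compound 2 and compound 3 cannot be told apart on this read-out, so at this position a sulfur-containing and an oxygen-containing five-membered aromatic ring are interchangeable in this pair, with the 3-hydroxyphenyl and 4-hydroxyphenyl groups kept in place. Nothing at hand gives a reason for this outcome.

Going by these compounds, the hetero atom and the point of attachment change together here, so their separate contributions stay open, and furan-3-yl or thiophen-2-yl would be needed to divide them. Also open, on these data alone, is how a primary amine, a carboxylic acid or a longer alkyl chain would fare at this position.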